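A few compounds are considered here, and "the series" means these few. Any claim that something is new, unique, unknown or untested is made for them only; others in the source may bear on it.

Three compounds have been measured in a functional assay on HCT-15 cells (Homo sapiens) for cytotoxicity, read by CCK-8 assay and cell counting, with a stated time of 2 days; a higher number here means a weaker inhibitor, a lower number a stronger inhibitor:

Compound 1 `Oc1ccc(-c2cc(-c3ccccc3)nc(-c3ccccc3Cl)c2)cc1`: 4990 nM
Compound 2 `Oc1cccc(-c2cc(-c3ccco3)nc(-c3ccccc3Cl)c2)c1`: 2230 nM
Compound 3 `Oc1cccc(-c2cc(-c3ccsc3)nc(-c3ccccc3Cl)c2)c1`: 2500 nM

Compound 3 sits second highest of the three numbers; its nearest neighbour is compound 2, and even the gap to compound 1 stays within the scatter, so all three are close. Compound 4 `Oc1cccc(-c2cc(-c3ccccc3)nc(-c3ccccc3Cl)c2)c1` differs from compound 3 in one place: phenyl in place of thiophen-3-yl on an aromatic carbon. Among the compounds with values here, the only measured step of this kind, a swap of one aromatic ring for another in the same place, was a 1.1-fold higher number from compound 2 to compound 3 (0.05 log units; within the scatter), which is small. Compound 1 already carries a phenyl in that place and gives a number close to compound 3. The expected change from compound 3 to compound 4 is therefore a 1.2-fold higher number from compound 3 to compound 4 (0.08 log units; within the scatter), nothing beyond the scatter. Compound 4 is estimated at 3000 nM, with a range from 1200 nM to 7500 nM.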

Compound 4, half-maximal inhibitory concentration: 2930 nM
Beside the measured number, compound 4's estimate is 1.0-fold (0.01 log units) above it; low and high end bracket the measured number.
By their numbers in this assay, from the lowest: compounds 2, 3, 4 and 1 (each within the scatter of the next, the first and the last beyond it).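

In this assay, the position next to the ring nitrogen accepts phenyl as readily as either five-membered aromatic ring, with a 1.2-fold higher number from compound 3 to compound 4 (0.07 log units; within the scatter) and a 1.3-fold higher number from compound 2 to compound 4 (0.12 log units; within the scatter). Moving the hydroxyl group, 3-hydroxyphenyl in place of 4-hydroxyphenyl, also stays small, with a 1.7-fold lower number from compound 1 to compound 4 (0.23 log units; within the scatter). No measurement is available to explain why these steps are so small.

All the groups compared at this position are aromatic rings. On these data alone, whether an amine, a carboxylic acid or a longer chain there would shift the number beyond the scatter remains open.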